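The source may hold more compounds than are shown below. What is called first, only, known or untested is meant among the compounds shown, and "the series" means these compounds.

Measured in an ADME assay on L1210/0 cells (Mus musculus) for cytotoxicity, with a stated time of 48 h; on this read-out higher numbers stand for weaker inhibition and lower numbers for stronger inhibition:
- compound 1 `COc1ccccc1C(=O)/C=C/c1cc(=O)[nH]c(=O)n1COCCO`: 15200 nM
- compound 2 `O=C(/C=C/c1cc(=O)[nH]c(=O)n1COCCO)c1ccccc1`: 43300 nM
- compound 3 `O=C1O/C(=C\Cn2cc(C(F)(F)F)c(=O)[nH]c2=O)C(OCc2ccccc2)=C1OCc1ccccc1`: 2000 nM

Of these three, compound 3 has the lowest number, and its gaps to the other two lie beyond the scatter. Next is compound 4 `O=C1O/C(=C\Cn2cc(Cl)c(=O)[nH]c2=O)C(OCc2ccccc2)=C1OCc1ccccc1`, with chloro in place of trifluoromethyl on an aromatic carbon.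

For the measured compounds named here, only one step has been measured, a 2.8-fold higher number from compound 1 to compound 2 (0.45 log units; beyond the scatter), with hydrogen in place of methoxy on an aromatic carbon. It is modest, but it involves different groups on a different structure, so it is only a rough guide to size. Going by the values given here, no measured step tests this exchange directly.

A modest step is therefore expected in this assay. The direction is tentatively upward, since compound 3 at 2000 nM is already the lowest of the three. The expected change is a 2.3-fold higher number from compound 3 to compound 4 (0.35 log units; beyond the scatter). Compound 4 is estimated at 4500 nM, within an expected range of 1200 nM to 17000 nM.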

Compound 4, half-maximal inhibitory concentration: 12200 nM
The estimate for compound 4 lay 2.7-fold (0.43 log units) below the measured number, within the range that was stated.
By their numbers in this assay, from the lowest: compound 3; then compounds 4 and 1 (each within the scatter of the next); then compound 2.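

In this assay, chloro in place of trifluoromethyl on this aromatic carbon gives a 6.1-fold higher number from compound 3 to compound 4 (0.79 log units; beyond the scatter). For the compounds shown here, this is the first direct reading at this position, and it shows that the number responds to the group held there, with trifluoromethyl giving the lower number of this pair. Nothing measured here explains the step.

As far as these compounds go, how a nitrile, an amine or a methyl group on this carbon would compare remains open. So does whether this exchange gives a step of similar size on another core.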